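This account rests on a few compounds, and the source may have more. Where it says the series, first, only, none or still open, it means among the compounds named here.

Compound 1 `CCCCOC(=O)Nc1cc2nc(C3CCCCC3)[nH]c2cc1N(C)C` gives > 100 ug/mL in an ADME assay on Vero cells (Chlorocebus sabaeus) for cytotoxicity, read by resazurin assay, with a stated time of 3 days (on this read-out higher numbers stand for weaker inhibition and lower numbers for stronger inhibition), a limit of the assay rather than a number.
Compound 2 `CN(C)c1cc2[nH]c(C3CCCCC3)nc2cc1NC(=O)c1ccc(C(C)(C)C)cc1` gives > 100 ug/mL in this assay, also a limit.
Compound 3 `CCCOCC(=O)Nc1cc2nc(C3CCCCC3)[nH]c2cc1N(C)C` gives < 50 ug/mL in this assay, again a limit.

All three share one core and differ only in the group attached to the carbonyl carbon of the amide. Compound 3 therefore stands alone at the lower side: its value is the limit of < 50 ug/mL in this assay, at which 1 of the 3 values shown sits, whereas the other two sit at the limit of > 100 ug/mL in this assay, at which 2 of the 3 values shown sit. The step from butoxy to the aryl group is a step that the two limits leave unreadable from compound 1 to compound 2; the steps toward the propoxymethyl compound are an at least 2.0-fold lower number from compound 1 to compound 3 (0.30 log units; that floor lies within the scatter) and an at least 2.0-fold lower number from compound 2 to compound 3 (0.30 log units; that floor lies within the scatter), both reaching only the floor that the limits allow.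

Compound 4 `CN(C)c1cc2[nH]c(C3CCCCC3)nc2cc1NC(=O)c1cccc(Br)c1` reverses the latter kind of change: 3-bromophenyl in place of propoxymethyl on a carbonyl carbon. Because the step of an at least 2.0-fold lower number from compound 2 to compound 3 (0.30 log units; that floor lies within the scatter) ran downward when an aryl group was replaced by propoxymethyl, putting an aryl group back is expected to carry the number upward, giving an at least 1.6-fold higher number from compound 3 to compound 4 (0.20 log units; that floor lies within the scatter). Compound 4 is thus estimated at 80 ug/mL, with a plausible range from 30 ug/mL to 150 ug/mL, and a fair chance that only a limit is reported.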

Compound 4, half-maximal inhibitory concentration: > 100 ug/mL
Compound 4: a limit, no number; the forecaster's own chance of this, stated with the estimate: 60%; middle value at least 1.2-fold (0.09 log units) from the limit.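

With 3-bromophenyl on the carbonyl carbon, compound 4 joins compound 1 and compound 2 at the upper limit of this assay: the limit of > 100 ug/mL in this assay, at which 3 of the 4 values shown sit. The change from propoxymethyl gives an at least 2.0-fold higher number from compound 3 to compound 4 (0.30 log units; that floor lies within the scatter), so a second aryl group, carrying a different substituent, also sits on the upper side, although the butoxy of compound 1, which has no ring, sits there too. The steps among compound 1, compound 2 and compound 4 cannot be read, as all three values are limits.

Going by these compounds, how far compound 3 lies under its limit, and the others over theirs, stays unknown, so the true size of the change does too. Also open, on these data alone, is whether the lower number goes with the oxygen in propoxymethyl or with the open chain itself, which a plain pentyl chain on the carbonyl carbon could separate.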